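A few compounds are considered here, and "the series" means these few. Any claim that something is new, unique, unknown or untested is made for them only; others in the source may bear on it.

For the measured compounds named here, in a physicochemical assay for solubility, at pH 7.4 (on this read-out higher numbers stand for higher solubility and lower numbers for lower solubility), compound 2 `CN1CCC(C(c2ccccc2)N2CCN(C(=O)CC(c3ccccc3)c3ccccc3)CC2)CC1` gives 63.6 ug/mL, the higher of the two numbers so far, while compound 1 `O=C(CC(c1ccccc1)c1ccccc1)N1CCN(C(c2ccccc2)c2ccccc2Cl)CC1` gives 0.37 ug/mL. Compound 3 `O=C(CC(c1ccccc1)c1ccccc1)N1CCN(C(c2ccccc2)c2cccc(C(F)(F)F)c2)CC1` carries 3-(trifluoromethyl)phenyl in place of the 1-methylpiperidin-4-yl of compound 2 on a saturated chain carbon bound to an amine nitrogen in a ring and an aromatic carbon: 3-(trifluoromethyl)phenyl in place of 1-methylpiperidin-4-yl on a saturated chain carbon bound to an amine nitrogen in a ring and an aromatic carbon. Going by the values given here, one measured step bears on this: a 170-fold higher number from compound 1 to compound 2 (2.24 log units; beyond the scatter), a large step that brought in 1-methylpiperidin-4-yl in place of 2-chlorophenyl at that same place. Here that group leaves again for an aromatic ring, so a similarly large step toward lower numbers is expected in this assay. The expected step is a 160-fold lower number from compound 2 to compound 3 (2.20 log units; beyond the scatter). For compound 3 the estimated value is 0.4 ug/mL, with an expected range of 0.1 ug/mL to 2 ug/mL.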

Compound 3, solubility: 0.14 ug/mL
Beside the measured number, compound 3's estimate is 2.9-fold (0.46 log units) above it, within the range that was stated.
By their numbers in this assay, from the lowest: compound 3; then compound 1; then compound 2.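

Putting an aromatic ring back at this position gives a 450-fold lower number from compound 2 to compound 3 (2.66 log units; beyond the scatter) in this assay, so the low number of compound 1 was not special to 2-chlorophenyl. The two aromatic groups still differ, with only a modest 2.6-fold lower number from compound 1 to compound 3 (0.42 log units; beyond the scatter), far smaller than either step involving 1-methylpiperidin-4-yl. Nothing measured here explains these steps. Still open, from the compounds shown here alone, is whether the ring nitrogen matters or simply the absence of an aromatic ring, which a cyclohexyl group at this place could separate. Where a piperidin-4-yl without the methyl would fall also remains open.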